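One Ring Swap and Its Expected Effect on Clearance

The source may hold more compounds than are shown below. What is called first, only, known or untested is meant among the compounds shown, and "the series" means these compounds.

Measured so far:
compound 1 `Cc1cc(C(C)NC(=O)c2[nH]cc(Cc3ccc(C(F)(F)F)nc3)c2C)no1`: 63000 mL.min-1.g-1
compound 2 `Cc1cc(Nc2ccc(S(F)(F)(F)(F)F)cc2)n2nc(C(F)(F)F)nc2n1`: < 7000 mL.min-1.g-1

Among the compounds with values here, in an ADME assay on microsomes from liver (Mus musculus) for metabolic stability, read by LC-MS, with a stated time of 4 h, tested at 1 uM (a lower number here means slower removal, a higher number faster removal of the compound), compound 1 gives the only real number, 63000 mL.min-1.g-1. For compound 2 only a limit of the assay is reported, < 7000 mL.min-1.g-1. That is the limit of < 7000 mL.min-1.g-1 in this assay, at which 1 of the 2 values shown sits. Compound 3 `Cc1c(Cc2ccc(C(F)(F)F)nc2)c[nH]c1C(=O)NC(C)c1cn[nH]c1` has not yet been measured. It differs from compound 1 in one place: 1H-pyrazol-4-yl in place of 5-methyl-1,2-oxazol-3-yl on a saturated chain carbon bound to an amide-type nitrogen and a saturated chain carbon. Within the data shown here, no measured pair shows this change, so its size is uncertain. A moderate drop in clearance is expected, a 2.1-fold lower number from compound 1 to compound 3 (0.32 log units; beyond the scatter). Compound 3 is expected to give 30000 mL.min-1.g-1, within 10000 mL.min-1.g-1 to 70000 mL.min-1.g-1.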

Compound 3, intrinsic clearance in microsomes in the Mus musculus assay: 31000 mL.min-1.g-1
Estimate against measurement, compound 3: 1.0-fold (0.01 log units) below, and the stated range covers the measured number.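

Within the data shown here, in the Mus musculus assay, placing 1H-pyrazol-4-yl where 5-methyl-1,2-oxazol-3-yl stood gives the first measured step at this place: a 2.0-fold lower number from compound 1 to compound 3 (0.31 log units; beyond the scatter). In a physicochemical assay for solubility, in simulated intestinal fluid, with a stated time of 5 h, at pH 6.5 (on this read-out higher numbers stand for higher solubility and lower numbers for lower solubility), compound 1 gives 9.9 ug/mL and compound 3 gives 34 ug/mL, which is a 3.4-fold higher number from compound 1 to compound 3 (0.54 log units; beyond the scatter). This single pair therefore shows lower clearance and higher solubility occurring together.

From the compounds shown here alone, what an amine or a carboxylic acid at this place would do to either read-out remains open. One pair also cannot separate the loss of the methyl from the change of ring atoms.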